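Hydroxyphenyl placement on a shared core: working notes

The compounds below may be only part of what the source reports. "The series", "measured", "known", "first", "only" and "open" are said of these compounds alone.

Measured so far in a functional assay on DU-145 cells (Homo sapiens) for inhibition; on this read-out higher numbers stand for weaker inhibition and lower numbers for stronger inhibition:
compound 1 `Oc1ccccc1-c1cc(-c2cccc(F)c2)cc(-c2ccccc2O)n1` — > 50000 nM
compound 2 `Oc1cccc(-c2cc(-c3cccc(F)c3)cc(-c3ccccc3O)n2)c1` — > 50000 nM
compound 3 `Oc1cccc(-c2cc(-c3ccccc3OC(F)(F)F)cc(-c3ccccc3O)n2)c1` — > 50000 nM

Each of these three values is a limit of this assay and not a number. For compound 1 the value > 50000 nM is a limit. For compound 2 the value > 50000 nM is likewise a limit. For compound 3 the value > 50000 nM is again a limit, and nothing finer than that is known for it.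

Within the data shown here, the one change that can be followed between measured compounds is 3-hydroxyphenyl in place of 2-hydroxyphenyl on an aromatic carbon. Its step, a step that the two limits leave unreadable from compound 1 to compound 2, stays unreadable because of the limit of > 50000 nM in this assay, at which 3 of the 3 values shown sit. How the core of compound 3 differs from the core of compound 1 is not broken down here.

Compound 4 `Oc1cccc(-c2cc(-c3ccccc3OC(F)(F)F)cc(-c3cccc(O)c3)n2)c1` is not yet measured. It stands to compound 3 as compound 2 stands to compound 1: 3-hydroxyphenyl in place of 2-hydroxyphenyl on an aromatic carbon. The surroundings are not the same word for word, though: in compound 3 the changed carbon is meta to a 3-hydroxyphenyl group and meta to a large group, whereas in compound 1 it is meta to a 2-hydroxyphenyl group and meta to a 3-fluorophenyl group. It is the same kind of change, not the same change.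

Since the earlier step could not be read, the expected step for compound 4 is a step that the limit leaves unreadable from compound 3 to compound 4, and this rests on compound 3 sitting at > 50000 nM with the same kind of change having moved nothing readable from compound 1 to compound 2. Compound 4 is therefore estimated at 70000 nM in this assay, within 30000 nM to 200000 nM, most likely reported as a limit.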

Compound 4, half-maximal inhibitory concentration: 5420 nM
Compound 4: the middle estimate sits 13-fold (1.11 log units) above what was measured; the whole stated range lies above it.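

In this assay, 3-hydroxyphenyl in place of 2-hydroxyphenyl gives an at least 9.2-fold lower number from compound 3 to compound 4 (0.96 log units; beyond the scatter), so on this core the change is readable and runs toward stronger inhibition, and its true size is bounded on one side only. Whether the same change does anything comparable on the core of compound 1 cannot be said, because the step there cannot be read: the limit of > 50000 nM in this assay, at which 3 of the 4 values shown sit.
The result therefore shows that the change can pay off on one core, but it neither shows that the change carries over from core to core nor shows that it fails to, and a single readable pair gives no rule for the series.

Still open is what an amine or a carboxylic acid would do in place of the hydroxyl on the 3-hydroxyphenyl group that enters, as every compound shown carries only hydroxyphenyl groups at these places. Equally open, going by these compounds, is how a longer chain would behave in place of the 3-fluorophenyl group of compound 2, or in place of the large group that compound 3 and compound 4 share.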